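The compounds below may be only part of what the source reports. "The series", "measured", "known", "first", "only" and "open" are said of these compounds alone.

Measured compounds:
- compound 1, `CC1CCCC(C(=O)N2CC(c3nc(-c4cccc(Cl)c4)no3)C2)C1`: > 10000 nM in an assay on HEK293 cells for negative allosteric modulation of metabotropic glutamate receptor 5 (Homo sapiens), read by FLIPR; on this read-out higher numbers stand for weaker inhibition and lower numbers for stronger inhibition
- compound 2, `O=C(C1CCCO1)N1CC(c2nc(-c3cccc(Cl)c3)no2)C1`: 890 nM in this assay
- compound 3, `O=C(C1CCC(F)(F)CC1)N1CC(c2nc(-c3cccc(Cl)c3)no2)C1`: > 10000 nM in this assay

The value of compound 1 is a limit of this assay, not a number. For compound 3 as well, the value in this assay is only a limit; it sits at the limit of > 10000 nM in this assay, at which 2 of the 3 values shown sit, so compound 3 is known merely to be weak, and how weak is not resolved. Compound 2 is the only one of the three with a number, and the step of an at least 11-fold higher number from compound 2 to compound 3 (1.05 log units; beyond the scatter) is large, while a step that the two limits leave unreadable from compound 1 to compound 3 cannot be read because both ends are limits.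

Compound 4, `Cc1cccc(-c2noc(C3CN(C(=O)C4CCC(F)(F)CC4)C3)n2)c1`, differs from compound 3 in one place: methyl in place of chloro on an aromatic carbon. Going by the values given here, none of the measured steps touches this position; every one of them changes the group on the carbonyl carbon, so there is no measured guide for this change. With compound 3 already at a limit, compound 4 is expected to remain weak, with the step that the limit leaves unreadable from compound 3 to compound 4 estimated as no clear shift. The estimate for compound 4 is 20000 nM, in the range 5000 nM to 80000 nM.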

Compound 4, half-maximal inhibitory concentration: > 10000 nM
Compound 4: a limit, no number; the forecaster's own chance of this, stated with the estimate: 80%; the middle value does not contradict the limit.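

In this assay compound 4 gives > 10000 nM, a limit and not a number. Compound 3 is likewise known only by a limit, so no step can be read between compound 3 and compound 4. The compounds shown leave open how weak both are, and whether methyl in place of chloro changes inhibition at all.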